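The source may report more compounds than this note shows. Statements on the series, on what has been measured and on what is new or still open speak of the compounds shown alone.

Three compounds of one series, each carrying the same core, have been measured in a functional assay on HT-29 cells (Homo sapiens) for antiproliferative activity, read by MTT assay, with a stated time of 48 h; on this read-out lower numbers stand for stronger inhibition and higher numbers for weaker inhibition. Compound 1 `O=C(/C=C\Nc1ccc(F)cc1)c1cn(-c2ccccc2)nc1-c1ccc(Cl)cc1` gives only a limit in this assay, > 50000 nM. Compound 2 `O=C(/C=C\Nc1ccc(O)cc1)c1cn(-c2ccccc2)nc1-c1ccc(Cl)cc1` gives 2500 nM in this assay. Compound 3 `COc1ccc(-c2nn(-c3ccccc3)cc2C(=O)/C=C\Nc2ccc(F)cc2)cc1` gives 7650 nM in this assay, the highest of the two numbers shown, with compound 2 the nearest neighbour.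

Two steps join these compounds. The change an at least 20-fold lower number from compound 1 to compound 2 (1.30 log units; beyond the scatter) was large, and the change an at least 6.5-fold lower number from compound 1 to compound 3 (0.81 log units; beyond the scatter) was at least modest; each starts from a limit (the limit of > 50000 nM in this assay, at which 1 of the 3 values shown sits), so the true size of either may be greater than stated.

Compound 4 `COc1ccc(-c2nn(-c3ccccc3)cc2C(=O)/C=C\Nc2ccc(O)cc2)cc1` differs from compound 3 in one place: hydroxy in place of fluoro on an aromatic carbon. Within the data shown here, the same change is the one seen from compound 1 to compound 2, where the number fell by at least the step of an at least 20-fold lower number from compound 1 to compound 2 (1.30 log units; beyond the scatter). It is therefore expected that the number for compound 4 in this assay falls clearly below that of compound 3, by a step estimated as a 15-fold lower number from compound 3 to compound 4 (1.18 log units; beyond the scatter). Compound 4 is estimated to give 500 nM in this assay, expected to lie between 100 nM and 2500 nM. The measured value follows.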

Compound 4, half-maximal inhibitory concentration: 2460 nM
Estimate against measurement, compound 4: 4.9-fold (0.69 log units) below, and the stated range covers the measured number.
By their numbers in this assay, from the lowest: compounds 4 and 2 (each within the scatter of the next); then compound 3. At a limit, above all of these: compound 1.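

Exchanging fluoro for hydroxy, here (4-fluorophenyl)amino to (4-hydroxyphenyl)amino, still lowers the number in this assay on the core of compound 3, with a 3.1-fold lower number from compound 3 to compound 4 (0.49 log units; beyond the scatter), so the direction of the change holds on both cores, but its size does not carry over from one to the other: the same change on two cores in this assay, an at least 20-fold lower number (1.30 log units; beyond the scatter) from compound 1 to compound 2 and a 3.1-fold lower number (0.49 log units; beyond the scatter) from compound 3 to compound 4, at least 6.4-fold (0.80 log units) apart, beyond the scatter of two such steps The change from chloro to methoxy behaves differently once hydroxy is present, with a 1.0-fold lower number from compound 2 to compound 4 (0.01 log units; within the scatter), so the drop seen among the fluoro compounds does not appear among the hydroxy compounds: the same change on two cores in this assay, an at least 6.5-fold lower number (0.81 log units; beyond the scatter) from compound 1 to compound 3 and a 1.0-fold lower number (0.01 log units; within the scatter) from compound 2 to compound 4, at least 6.4-fold (0.80 log units) apart, beyond the scatter of two such steps Compound 1 stands at a limit, so each of these gaps is only a lower bound: the limit of > 50000 nM in this assay, at which 1 of the 4 values shown sits.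

The compounds shown leave open whether the hydroxy group itself is needed at this position, or whether an amino group or a methoxy group there would give a similar number. They also leave open whether the level reading of the two hydroxy compounds would persist with a methyl group or a bromo group in place of chloro or methoxy on the other aromatic ring.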